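This account rests on a few compounds, and the source may have more. Where it says the series, first, only, none or still open, it means among the compounds named here.

Series notes. Compound 1 `O=c1[nH]/c(=N\OCCCc2cccc(F)c2)ccn1[C@@H]1O[C@H](COP(=O)(O)OP(=O)(O)OP(=O)(O)O)[C@@H](O)[C@H]1O` carries a 3-fluorophenyl on the chain; in a functional assay on 1321-N1 cells for agonist activity at P2Y purinoceptor 4 (Homo sapiens), read by scintillation counting and inositol phosphate accumulation (on this read-out lower numbers stand for an effect already at smaller amounts and higher numbers for an effect only at larger amounts of compound), compound 1 gives 100 nM. Compound 2 `O=c1[nH]/c(=N\OCCCc2ccc(I)cc2)ccn1[C@@H]1O[C@H](COP(=O)(O)OP(=O)(O)OP(=O)(O)O)[C@@H](O)[C@H]1O` carries 4-iodophenyl at the same place; in this assay compound 2 gives 91 nM. For the measured compounds named here, the one step so far, a 1.1-fold lower number from compound 1 to compound 2 (0.04 log units; within the scatter), shows that swapping the ring at this place barely moves the read-out. Of the two numbers that of compound 2 is the lowest, but its distance to compound 1 lies within the scatter, so the two cannot be told apart.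

Compound 3 `O=c1[nH]/c(=N\OCCCc2cccc([N+](=O)[O-])c2)ccn1[C@@H]1O[C@H](COP(=O)(O)OP(=O)(O)OP(=O)(O)O)[C@@H](O)[C@H]1O` is unmeasured; it differs from compound 2 by 3-nitrophenyl in place of 4-iodophenyl on a saturated chain carbon, three bonds along the chain from an oxygen. Going by the values given here, the only step bearing on this place, a 1.1-fold lower number from compound 1 to compound 2 (0.04 log units; within the scatter), was flat, and no phenyl bearing a nitro group has yet been tested in this assay. Compound 3 is therefore expected to show a step of about a 1.2-fold higher number from compound 2 to compound 3 (0.08 log units; within the scatter), nothing beyond the scatter. Compound 3 is estimated at 110 nM in this assay, within a range from 45 nM to 270 nM.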

Compound 3, half-maximal effective concentration: 95 nM
Compound 3: middle estimate off by 1.2-fold (0.06 log units), on the high side; low and high end bracket the measured number.
By their numbers in this assay, from the lowest: compounds 2, 3 and 1 (each within the scatter of the next).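

In this assay the step of a 1.0-fold higher number from compound 2 to compound 3 (0.02 log units; within the scatter) is flat, so 3-nitrophenyl and 4-iodophenyl on the chain cannot be told apart, even though the entering group counts two hydrogen-bond acceptors and the leaving group none. The step of a 1.1-fold lower number from compound 1 to compound 3 (0.02 log units; within the scatter) gives a second reading, a swap of nitro for fluoro on an aromatic carbon, and it too stays within the scatter, so compound 1, compound 2 and compound 3 form one level with three different ring groups. Nothing measured on these groups bears on why the read-out stays flat.

From the compounds shown here alone, whether this level holds for a phenyl carrying an amine or a carboxylic acid remains open. Also open, going by these compounds, is what a longer chain, or a plain methyl in place of the ring, would do at this position.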